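From a Hydroxylated Phenyl Group to a Methylthiophene

A few compounds are considered here, and "the series" means these few. Any claim that something is new, unique, unknown or untested is made for them only; others in the source may bear on it.

Two close relatives have been measured so far, and they differ only in the aromatic group carried on the chain of the shared core. In a functional assay on MCF7 cells (Homo sapiens) for cytotoxicity (a lower number here means a stronger inhibitor, a higher number a weaker inhibitor), compound 1 (`C=C/C=C\[C@H](C)[C@H](OC(N)=O)[C@@H](C)[C@H](O)[C@@H](C)C/C(C)=C\[C@H](C)[C@@H](O)[C@@H](C)/C=C\CCc1cccc(F)c1`) gives 370 nM, and compound 2 (`C=C/C=C\[C@H](C)[C@H](OC(N)=O)[C@@H](C)[C@H](O)[C@@H](C)C/C(C)=C\[C@H](C)[C@@H](O)[C@@H](C)/C=C\CCc1ccc(C)c(O)c1`) gives 770 nM. Compound 2 therefore holds the higher of the two numbers, which makes it the weaker inhibitor of the pair.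

Compound 3 (`C=C/C=C\[C@H](C)[C@H](OC(N)=O)[C@@H](C)[C@H](O)[C@@H](C)C/C(C)=C\[C@H](C)[C@@H](O)[C@@H](C)/C=C\CCc1sccc1C`) is changed at the same place: 3-methylthiophen-2-yl in place of 3-hydroxy-4-methylphenyl on a saturated chain carbon, two bonds along the chain from a double-bonded chain carbon. In short, 3-methylthiophen-2-yl stands in place of 3-hydroxy-4-methylphenyl. Among the measured compounds shown here, only one measured step bears on this change, a 2.1-fold higher number from compound 1 to compound 2 (0.32 log units; beyond the scatter), and it is modest and involves different groups. It suggests a small move at this place, not a rule. Like compound 3, compound 1 has no hydroxy group, and it gives 370 nM, so a slightly lower number is expected. The estimated change is a 1.4-fold lower number from compound 2 to compound 3 (0.15 log units; within the scatter), which would stay within the scatter. For compound 3 the estimated value in this assay is 550 nM, with an expected range of 180 nM to 1600 nM.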

Compound 3, half-maximal inhibitory concentration: 370 nM
Compound 3: the middle estimate sits 1.5-fold (0.17 log units) above what was measured; measured number inside the range.
By their numbers in this assay, from the lowest: compounds 1 and 3 (each within the scatter of the next); then compound 2.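

In this assay, replacing the 3-hydroxy-4-methylphenyl group with 3-methylthiophen-2-yl gives a 2.1-fold lower number from compound 2 to compound 3 (0.32 log units; beyond the scatter) and shows that the number at this place can come back down after the rise seen with compound 2. Against the 3-fluorophenyl group, the same thiophene group gives no change at the digits printed from compound 1 to compound 3 (within the scatter) and so shows that a six-membered aromatic ring of carbon only is not required here: a five-membered aromatic ring with one hetero atom serves equally well in this assay. Compound 2 is now the only one of the three with a hydroxy group and also has the highest number, but with so few compounds this is an observation and not a rule.

No supporting data are available to give a reason for these numbers. Still open, from the compounds shown here alone, is how an amine or a carboxylic acid on the aromatic ring would behave at this place, and whether a longer chain leading to the ring would leave the number where compound 1 and compound 3 stand.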